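A Methoxy Group Added to Compound 3

The compounds below may be only part of what the source reports. "The series", "measured", "known", "first", "only" and "open" are said of these compounds alone.

Measured compounds and their values:
compound 1 `COC(=O)[C@@]1(C)CCC=C2[C@@H]1CC[C@@H](C)[C@]2(C)Cc1c[nH]c2ccccc12`: 4500 nM
compound 2 `COC(=O)[C@@]1(C)CCC=C2[C@@H]1CC[C@@H](C)[C@]2(C)Cc1c[nH]c2ccc(C(F)(F)F)cc12`: 15000 nM
compound 3 `COC(=O)[C@@]1(C)CCC=C2[C@@H]1CC[C@@H](C)[C@]2(C)Cc1c(C)[nH]c2ccccc12`: 14000 nM

In a functional assay on HBL-100 cells (Homo sapiens) for inhibition, read by sulforhodamine B assay, with a stated time of 48 h (a lower number here means a stronger inhibitor of growth, a higher number a weaker inhibitor of growth), compound 1 gives 4500 nM. Compound 2 gives 15000 nM, and compound 3 gives 14000 nM. Compound 3 therefore stands second highest of the three numbers; its value and that of compound 2 lie within the scatter of each other, while the step of a 3.1-fold higher number from compound 1 to compound 3 (0.49 log units; beyond the scatter) lies beyond it.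

Compound 4 `COC(=O)[C@@]1(C)CCC=C2[C@@H]1CC[C@@H](C)[C@]2(C)Cc1c(C)[nH]c2ccc(OC)cc12` differs from compound 3 by methoxy in place of hydrogen on an aromatic carbon.

Among the compounds with values here, two measured steps bear on this change, both adding a group on an aromatic carbon of the shared core: a 3.3-fold higher number from compound 1 to compound 2 (0.52 log units; beyond the scatter) and a 3.1-fold higher number from compound 1 to compound 3 (0.49 log units; beyond the scatter). Each was a modest rise in the number. Methoxy is a different group from either, so the comparison is loose, but the direction seen so far is a weakening. The expected step is therefore a 1.4-fold higher number from compound 3 to compound 4 (0.15 log units; within the scatter), a modest rise at most. Compound 4 is thus estimated at 20000 nM, with a range from 7000 nM to 60000 nM.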

Compound 4, concentration for 50% growth inhibition: 16000 nM
Beside the measured number, compound 4's estimate is 1.3-fold (0.10 log units) above it, and the stated range covers the measured number.
By their numbers in this assay, from the lowest: compound 1; then compounds 3, 2 and 4 (each within the scatter of the next).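

In this assay, the step of a 1.1-fold higher number from compound 3 to compound 4 (0.06 log units; within the scatter) shows that methoxy in place of hydrogen on this aromatic carbon, para to a fused ring, leaves the number within the scatter. Until now, both single changes had raised the number beyond the scatter: a 3.3-fold higher number from compound 1 to compound 2 (0.52 log units; beyond the scatter) for trifluoromethyl and a 3.1-fold higher number from compound 1 to compound 3 (0.49 log units; beyond the scatter) for methyl, so an added group on an aromatic carbon of this core does not always bring a measurable loss of growth inhibition. No measurement here explains why the methoxy step stays so small.

Still open, from the compounds shown here alone, is whether methoxy would act in the same way on compound 1, which lacks the methyl group of compound 3. Going by these compounds, it is also open how an amine or a carboxylic acid on this same carbon would shift the number.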